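The source may hold more compounds than are shown below. What is called first, only, known or untested is meant among the compounds shown, and "the series" means these compounds.

Compound 1 (`CC(C)c1[nH]cnc1/C=c1\[nH]c(=O)/c(=C/c2cccc(Oc3ccc(F)cc3)c2)[nH]c1=O`) gives 8.8 nM in a functional assay on NCI-H460 cells (Homo sapiens) for cytotoxicity, read by MTT assay, with a stated time of 72 h; a lower number here means a stronger inhibitor, a higher number a weaker inhibitor
Compound 2 (`CC(C)c1[nH]cnc1/C=c1\[nH]c(=O)/c(=C/c2cccc(C(=O)c3ccc(F)cc3)c2)[nH]c1=O`) gives 3.2 nM in this assay

Compound 2 holds the lower of the two numbers, so it is the stronger inhibitor measured so far. Going by the values given here, the only measured step is a 2.8-fold lower number from compound 1 to compound 2 (0.44 log units; beyond the scatter), which is modest but beyond the scatter. That step puts (4-fluorophenyl)carbonyl in place of 4-fluorophenoxy on an aromatic carbon.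

Compound 3 (`O=C(c1ccc(F)cc1)c1cccc(/C=c2\[nH]c(=O)/c(=C/c3nc[nH]c3C3CC3)[nH]c2=O)c1`) has not yet been measured. It keeps the (4-fluorophenyl)carbonyl group of compound 2 and differs elsewhere: cyclopropyl in place of isopropyl on an aromatic carbon. In short, it has cyclopropyl in place of isopropyl on an aromatic carbon, and the group changes from 5-isopropyl-1H-imidazol-4-yl to 5-cyclopropyl-1H-imidazol-4-yl.

Among the compounds with values here, no measured step touches this place, so the data show no direction for the change. Within the data shown here, the one measured step, a 2.8-fold lower number from compound 1 to compound 2 (0.44 log units; beyond the scatter), serves only as a rough guide to size, since it replaced a much larger group and stayed modest. A small swap is therefore expected to shift this assay little, with no clear change beyond the scatter. The expected step is a 1.4-fold higher number from compound 2 to compound 3 (0.15 log units; within the scatter), though this is only an estimate. For compound 3 the estimated value is 4.5 nM, with an expected range from 1.5 nM to 14 nM.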

Compound 3, half-maximal inhibitory concentration: 2.8 nM
The estimate for compound 3 lay 1.6-fold (0.21 log units) above the measured number, and the stated range covers the measured number.
By their numbers in this assay, from the lowest: compounds 3 and 2 (each within the scatter of the next); then compound 1.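

In this assay, the change from 5-isopropyl-1H-imidazol-4-yl to 5-cyclopropyl-1H-imidazol-4-yl gives a 1.1-fold lower number from compound 2 to compound 3 (0.06 log units; within the scatter), so closing the open isopropyl group into a three-membered ring of carbon leaves no difference that can be told from ordinary repeat variation. Going by these compounds alone, this is the first reading at this position, as the earlier step concerned a different part of the molecule, and it shows that the position accepts this swap with compound 3 still at 2.8 nM. No measurement shown here explains why the two groups read alike.

Isopropyl and cyclopropyl are both small carbon groups with the same count of heavy atoms, so this pair says little about how a clearly different group at this position would behave, such as an amine, a carboxylic acid or a longer chain like n-butyl. It also leaves open whether the same swap would read alike with the 4-fluorophenoxy group of compound 1 in place of the (4-fluorophenyl)carbonyl group.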